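Adding Two Chlorines to the Benzyl Ether of Compound 3

The compounds below may be only part of what the source reports. "The series", "measured", "known", "first", "only" and "open" are said of these compounds alone.

Among the compounds with values here, compound 3 `Cc1ccc(NC(=O)NC(=O)c2ccc(OCc3ccccc3)cc2)cc1-c1nc2ccccc2[nH]1` is one of three compounds measured in a functional assay on HT-29 cells (Homo sapiens) for inhibition, read by MTT assay, with a stated time of 48 h; a higher number here means a weaker inhibitor, a lower number a stronger inhibitor. Compound 1 `Cc1ccc(NC(=S)NC(=O)c2ccc(OCc3cccc(F)c3)cc2)cc1-c1nc2ccccc2[nH]1` gives 55300 nM in this assay, compound 2 `Cc1ccc(NC(=S)NC(=O)c2ccc(OCc3ccc(Cl)cc3Cl)cc2)cc1-c1nc2ccccc2[nH]1` gives 11600 nM, and compound 3 gives 16400 nM. Compound 3 thus holds the second highest number of the three: its gap to compound 2 lies within the scatter, while its gap to compound 1 lies beyond it.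

Compound 4 `Cc1ccc(NC(=O)NC(=O)c2ccc(OCc3ccc(Cl)c(Cl)c3)cc2)cc1-c1nc2ccccc2[nH]1` has not yet been measured. It differs from compound 3 in one place: 3,4-dichlorophenyl in place of phenyl on a saturated chain carbon bound to an oxygen on an aromatic ring

Within the data shown here, the one measured single-point step, a 4.8-fold lower number from compound 1 to compound 2 (0.68 log units; beyond the scatter), bears on this change: there too a phenyl carrying chlorines replaced a phenyl carrying a single fluorine on a saturated chain carbon bound to an oxygen on an aromatic ring, and the number fell modestly. Compound 4 shares neither those exact groups nor the rest of its structure with that pair, so the step is a guide only. A modest fall in this assay is therefore expected from compound 3 to compound 4, a 2.3-fold lower number from compound 3 to compound 4 (0.37 log units; beyond the scatter). Compound 4 is estimated at 7000 nM, with an expected range from 2500 nM to 20000 nM.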

Compound 4, half-maximal inhibitory concentration: 1030 nM
Compound 4: the middle estimate sits 6.8-fold (0.83 log units) above what was measured; the whole stated range lies above it.
By their numbers in this assay, from the lowest: compound 4; then compounds 2 and 3 (each within the scatter of the next); then compound 1.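

In this assay, 3,4-dichlorophenyl in place of phenyl on a saturated chain carbon bound to an oxygen on an aromatic ring gives a 16-fold lower number from compound 3 to compound 4 (1.20 log units; beyond the scatter), a large step. The earlier step, a 4.8-fold lower number from compound 1 to compound 2 (0.68 log units; beyond the scatter), exchanged one substituted phenyl for another in compounds carrying a thiocarbonyl, whereas this one starts from the bare phenyl and keeps the carbonyl of compound 3, showing that this position can move the number strongly on that structure. No measurement shown here accounts for the size of this step.

From the compounds shown here alone, it remains open whether a single chlorine, as in 4-chlorophenyl, would give a step of this size, and what a trifluoromethyl or methoxy group would do at this place. Also open, going by these compounds, is whether 3,4-dichlorophenyl would act the same way in the thiocarbonyl compounds.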